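Ester chain variation in a calcium channel series

This account rests on a few compounds, and the source may have more. Where it says the series, first, only, none or still open, it means among the compounds named here.

Compound 1 `CCOC(=O)C1=C(C)NC(C)=C(C(=O)OC)C1c1[nH]c(CC)nc1Cl` gives 2.02 nM in an assay on ileum for inhibition of Voltage-dependent L-type calcium channel subunit alpha-1C (Cavia porcellus) (a higher number here means a weaker inhibitor, a lower number a stronger inhibitor), the highest number among the three measured compounds; compound 2 `CCCOC(=O)C1=C(C)NC(C)=C(C(=O)OC)C1c1[nH]c(CC)nc1Cl` gives 0.146 nM and compound 3 `CCCOC(=O)C1=C(C)NC(C)=C(C(=O)OCCC)C1c1[nH]c(CC)nc1Cl` gives 0.13 nM. The change to compound 4 `CCOC(=O)C1=C(C)NC(C)=C(C(=O)OC(C)(C)C)C1c1[nH]c(CC)nc1Cl` is tert-butyl in place of methyl on an oxygen next to a carbonyl group. Among the measured compounds shown here, two measured steps bear on it. Lengthening the chain on the other ester gave a 14-fold lower number from compound 1 to compound 2 (1.14 log units; beyond the scatter), a large step. Extending the chain on this same oxygen gave a 1.1-fold lower number from compound 2 to compound 3 (0.05 log units; within the scatter), a step within the scatter. For the measured compounds named here, the change in compound 4 sits at the position that showed no effect on extension, while a branched tert-butyl group has no measured counterpart anywhere, so the branching itself is untested. For compound 4 the expected step from compound 1 is small, at most a modest lowering, with wide uncertainty, a 2.2-fold lower number from compound 1 to compound 4 (0.35 log units; beyond the scatter). Compound 4 is therefore estimated to give 0.9 nM in this assay, with a range from 0.15 nM to 5 nM.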

Compound 4, half-maximal inhibitory concentration: 99.8 nM
Compound 4: the middle estimate sits 110-fold (2.04 log units) below what was measured; measured number outside the range, above it.
By their numbers in this assay, from the lowest: compounds 3 and 2 (each within the scatter of the next); then compound 1; then compound 4.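

In this assay, the position on the oxygen next to a carbonyl group proves sensitive to what it carries: tert-butyl in place of methyl gives a 49-fold higher number from compound 1 to compound 4 (1.69 log units; beyond the scatter), whereas adding ethyl at the same position gave a 1.1-fold lower number from compound 2 to compound 3 (0.05 log units; within the scatter). The position therefore tolerates one change but not the other, although the two steps differ in the ester carried on the other side of the core, so the contrast is only indicative. No supporting measurement accounts for the rise in the number.

The compounds shown leave open whether the loss follows from branching or from the tert-butyl group specifically, a question that an isopropyl or a longer unbranched chain on this oxygen would help to settle. They also leave open whether tert-butyl has the same effect alongside the other ester of compound 2.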